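The compounds below may be only part of what the source reports. "The series", "measured", "known", "first", "only" and "open" are said of these compounds alone.

Of the compounds shown here, three built on a shared core have been tested in a functional assay on MM1.S cells (Homo sapiens) for cytotoxicity, read by MTT assay, with a stated time of 48 h; on this read-out higher numbers stand for weaker inhibition and lower numbers for stronger inhibition. Compound 1 `ClC1=C(Cl)C(Cl)=C(Cl)C1=NN(c1ccccc1)c1ccccc1` gives > 3000 nM, which is a limit of the assay and not a number. Compound 2 `Fc1ccccc1NN=C1C(Cl)=C(Cl)C(Cl)=C1Cl` gives > 3000 nM, which is likewise only a limit. Within the data shown here, compound 3 `Fc1cccc(NN=C2C(Cl)=C(Cl)C(Cl)=C2Cl)c1` gives 1500 nM, and this is the only true number in the set, so compound 3 is the sole point from which a measured comparison can start.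

The next compound, compound 4 `ClC1=C(Cl)C(Cl)=C(Cl)C1=NNc1ccccc1`, has not yet been measured. It differs from compound 3 in one place, with hydrogen in place of fluoro on an aromatic carbon. Among the measured compounds shown here, no pair of measured compounds here differs in one place, so the data give no direct guide to the size of such a change. The expectation therefore rests on compound 3 at 1500 nM, and it is for a small move toward weaker inhibition, possibly no larger than the usual scatter. The expected step is a 1.5-fold higher number from compound 3 to compound 4 (0.17 log units; within the scatter). A result reported only as a limit in this assay would also not be surprising. For compound 4 the estimated value is 2200 nM, with an expected range of 900 nM to 5000 nM.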

Compound 4, half-maximal inhibitory concentration: 2000 nM
Estimate against measurement, compound 4: 1.1-fold (0.04 log units) above, and the stated range covers the measured number.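

In this assay, the step with hydrogen in place of fluoro on an aromatic carbon, meta to a large group, is a 1.3-fold higher number from compound 3 to compound 4 (0.12 log units; within the scatter), so the two compounds cannot be told apart and the fluoro at this place is not needed for the activity seen here. The same swap, read from the other fluorinated compound, gives an at least 1.5-fold lower number from compound 2 to compound 4 (0.17 log units; that floor lies within the scatter), while hydrogen in place of phenyl on a nitrogen gives an at least 1.5-fold lower number from compound 1 to compound 4 (0.17 log units; that floor lies within the scatter). Those two steps are floors and not full sizes, and the true gaps could be larger, because each starts from a value that is a limit of the assay and not a number: the limit of > 3000 nM in this assay, at which 2 of the 4 values shown sit.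

The compounds shown leave open what a chlorine, a methoxy group or an amine would do on this aromatic carbon, as hydrogen and fluoro are the only two groups compared there. Also open, going by these compounds, is what a small group such as methyl would do on the nitrogen, where only hydrogen and phenyl appear.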